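The source may hold more compounds than are shown below. What is called first, only, known or untested is meant among the compounds shown, and "the series" means these compounds.

Measured so far in an ADME assay on LLC-MK2 cells (Macaca mulatta) for cytotoxicity, read by MTT assay, with a stated time of 48 h; a lower number here means that less compound is tolerated, a higher number that more compound is tolerated:

- Compound 1 `C/C(=C\c1ccccc1)C(=O)/C=C/c1ccccc1`: 33600 nM
- Compound 2 `COc1ccc(/C=C/C(=O)/C(C)=C/c2ccccc2)cc1`: 93000 nM
- Compound 3 `COc1ccc(/C=C/C(=O)/C(C)=C/c2ccc(OC)cc2)cc1`: 75000 nM

Compound 3, at 75000 nM, sits level with compound 2 within the scatter and has a higher number than compound 1. Compound 4 `COc1ccc(/C=C(\C)C(=O)/C=C/c2ccc(N(C)C)cc2)cc1` carries dimethylamino in place of methoxy on an aromatic carbon, para to a large group (dimethylamino in place of methoxy on an aromatic carbon). Among the compounds with values here, no measured step makes this swap. The closest evidence is two steps that put methoxy in place of hydrogen: a 2.8-fold higher number from compound 1 to compound 2 (0.44 log units; beyond the scatter) and a 1.2-fold lower number from compound 2 to compound 3 (0.09 log units; within the scatter). Neither gives a firm direction, so only a small change is expected in this assay, perhaps none beyond the scatter. The expected step is a 1.3-fold lower number from compound 3 to compound 4 (0.10 log units; within the scatter) and remains uncertain. Compound 4 is estimated at 60000 nM (expected range 20000 nM to 160000 nM).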

Compound 4, half-maximal cytotoxic concentration: 411000 nM
The estimate for compound 4 lay 6.9-fold (0.84 log units) below the measured number, and the stated range ends below it.
By their numbers in this assay, from the lowest: compound 1; then compounds 3 and 2 (each within the scatter of the next); then compound 4.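

In this assay, dimethylamino in place of methoxy on this aromatic carbon, para to a large group, gives a 5.5-fold higher number from compound 3 to compound 4 (0.74 log units; beyond the scatter), so more compound is tolerated. The earlier steps shown here only put methoxy in place of hydrogen; this one exchanges one group for another at a substituted position, and the number moves beyond the scatter. Nothing measured here accounts for this shift. The compounds shown leave open whether a primary amine, a hydroxyl or a diethylamino group at this position would move the number the same way.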